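The compounds below may be only part of what the source reports. "The series", "measured", "known", "first", "only" and "open" are said of these compounds alone.

Measured so far:
compound 1 `CCOC(=O)c1sc(-c2cccc(NC(=O)c3ccc(C(F)(F)F)cc3)c2)nc1Nc1ccc(N2CCN(C)CC2)cc1` gives 18.4%
compound 2 `CCOC(=O)c1sc(-c2cccc(NC(=O)c3ccccc3)c2)nc1Nc1ccc(N2CCN(C)CC2)cc1` gives 77.1%
compound 3 `CN1CCN(c2ccc(Nc3nc(-c4cccc(NC(=O)c5ccc(C(F)(F)F)cc5)c4)sc3C(N)=O)cc2)CC1` gives 97.8%

In a functional assay on Ramos cells (Homo sapiens) for antiproliferative activity, read by CCK-8 assay, with a stated time of 72 h, tested at 40 uM (on this read-out lower numbers stand for less inhibition and higher numbers for more inhibition at the one concentration tested (going by the name of the read-out)), compound 3 stands highest of the three, with compound 2 nearest and compound 1 furthest. Compound 4 `CN1CCN(c2ccc(Nc3nc(-c4cccc(NC(=O)[C@H]5CC[C@H](C)CC5)c4)sc3C(N)=O)cc2)CC1` differs from compound 3 by one change: 4-methylcyclohexyl in place of 4-(trifluoromethyl)phenyl on a carbonyl carbon. For the measured compounds named here, no measured step swaps an aromatic ring for a non-aromatic one. The closest guide is a number 58.7 percentage points higher from compound 1 to compound 2 (beyond the scatter), where losing trifluoromethyl from the same ring raised inhibition strongly; here trifluoromethyl also leaves. Compound 3 already has a number near the top of the scale in this assay, so little room for an upward step remains. Compound 4 is therefore expected to stay high, with a step of a number 7.8 percentage points lower from compound 3 to compound 4 (within the scatter). The estimate for compound 4 is 90%, likely between 60% and 100%.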

Compound 4, a percentage reported as inhibition, at one concentration (the size of the read-out at that concentration, not a potency): 55.1%
For compound 4 the middle estimate is 34.9 percentage points above the measured one, and the stated range ends above it.
By their numbers in this assay, from the lowest: compound 1; then compound 4; then compound 2; then compound 3.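

In this assay, putting 4-methylcyclohexyl in place of 4-(trifluoromethyl)phenyl on this carbonyl carbon gives a number 42.7 percentage points lower from compound 3 to compound 4 (beyond the scatter). For the compounds shown here, this is the first sign that the ring at this position matters: with the amino group kept on the other carbonyl, the aromatic ring cannot be exchanged for this non-aromatic one without a clear loss. No measurement at hand explains the drop.

Still open, as far as these compounds go, is whether the loss follows from the change of ring or from the loss of trifluoromethyl, a question that an unsubstituted phenyl or cyclohexyl ring could help separate. From the compounds shown here alone, how a ring carrying an amine, such as piperidine, would behave on this carbonyl carbon is also open.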